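This account rests on a few compounds, and the source may have more. Where it says the series, first, only, none or still open, it means among the compounds named here.

Of the compounds shown here, two have so far been measured in an assay on isolated protein for displacement of a labelled ligand from Apoptosis regulator Bcl-2 (Homo sapiens), read by fluorescence polarization; on this read-out lower numbers stand for stronger inhibition and higher numbers for weaker inhibition. Compound 1 `CCCCCC1(OC)CCN(c2ccc(C(=O)NS(=O)(=O)c3ccc(N[C@H](CCN(C)C)CSc4ccccc4)c([N+](=O)[O-])c3)cc2)CC1` gives 20 nM in this assay. Compound 2 `COc1ccccc1CC1(OC)CCN(c2ccc(C(=O)NS(=O)(=O)c3ccc(N[C@H](CCN(C)C)CSc4ccccc4)c([N+](=O)[O-])c3)cc2)CC1` gives 1.6 nM in this assay. Among the compounds with values here, the single step between them, a 13-fold lower number from compound 1 to compound 2 (1.10 log units; beyond the scatter), came from putting 2-methoxyphenyl in place of butyl on a saturated chain carbon bound to a saturated ring carbon. Compound 2 thus holds the lowest of the two numbers, with compound 1 the nearest neighbour at a clearly higher number.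

Compound 3 `COC1(Cc2ccccc2Br)CCN(c2ccc(C(=O)NS(=O)(=O)c3ccc(N[C@H](CCN(C)C)CSc4ccccc4)c([N+](=O)[O-])c3)cc2)CC1` has not yet been measured. It differs from compound 2 by bromo in place of methoxy on an aromatic carbon, ortho to a large group; read one bond further out, 2-methoxyphenyl becomes 2-bromophenyl. Within the data shown here, no measured step bears on this change: the only step seen, from compound 1 to compound 2, replaced the whole 2-methoxyphenyl and tells nothing about exchanging one group on that ring for another. With no guide in the data, a step no larger than the scatter is expected. Compound 3 is therefore estimated at 2 nM, within 0.7 nM to 6 nM, which would mean a 1.3-fold higher number from compound 2 to compound 3 (0.10 log units; within the scatter) in this assay.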

Compound 3, inhibition constant: 1.5 nM
Beside the measured number, compound 3's estimate is 1.3-fold (0.12 log units) above it; the range from low to high includes it.
By their numbers in this assay, from the lowest: compounds 3 and 2 (each within the scatter of the next); then compound 1.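

In this assay, bromo in place of methoxy on an aromatic carbon, ortho to a large group, gives a 1.1-fold lower number from compound 2 to compound 3 (0.03 log units; within the scatter), so the two groups cannot be told apart at this position, even though methoxy counts a hydrogen-bond acceptor and bromo counts none. The large step away from the butyl compound therefore does not depend on methoxy: 2-bromophenyl in place of butyl gives a 13-fold lower number from compound 1 to compound 3 (1.12 log units; beyond the scatter), a step much like the earlier 13-fold lower number from compound 1 to compound 2 (1.10 log units; beyond the scatter), and what the two aromatic compounds share is the ring rather than this particular group on it. No measurement at hand bears on why methoxy and bromo read alike here.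

The compounds shown leave open how a plain benzyl with nothing on this aromatic carbon would read in this assay, and how an amine or a carboxylic acid would read at the same place. From the compounds shown here alone, it also remains open whether methoxy and bromo would still match each other on the other carbons of that ring.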